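The source may report more compounds than this note shows. Statements on the series, on what has been measured and on what is new or still open speak of the compounds shown alone.

Working notes on the series.

Compound 1 `COc1ccccc1/C=c1\c(=O)[nH]/c(=C/c2cccc(Cl)c2Cl)c(=O)n1C` and compound 2 `COc1ccccc1/C=c1\c(=O)[nH]/c(=C/c2ccccc2Cl)c(=O)n1C` share the core and differ only in the ring that is not methoxy-bearing. In a functional assay on A549 cells (Homo sapiens) for cytotoxicity, read by CCK-8 assay, with a stated time of 72 h (a higher number here means a weaker inhibitor, a lower number a stronger inhibitor), compound 1 gives 200 nM, and compound 2 gives 300 nM. The step of a 1.5-fold higher number from compound 1 to compound 2 (0.18 log units; within the scatter) shows that removing one chloro from that ring leaves the read-out within the scatter.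

Compound 3 `C=CCn1c(=O)/c(=C\c2ccc(F)c(Br)c2)[nH]c(=O)/c1=C\c1ccccc1OC` carries an allyl on the ring nitrogen and a different aryl on the same side. In this assay compound 3 is reported as "not active" (no number reported), with no number given, so it stands apart from compound 1 and compound 2 without a measured gap.

Compound 4 `C=CCn1c(=O)/c(=C\c2ccc(C)cc2)[nH]c(=O)/c1=C\c1ccccc1OC` is not yet measured. It differs from compound 3 by 4-methylphenyl in place of 3-bromo-4-fluorophenyl on a double-bonded chain carbon bound to an aromatic carbon. Among the compounds with values here, the only measured step, that from compound 1 to compound 2, concerns a halogen change on the corresponding ring and was within the scatter; no step starts from compound 3 itself, and compound 3 has no number to step from. The aryl exchange here is larger than a single halogen removal, and the allyl on compound 3 is shared by compound 4, so the expectation leans toward weak inhibition with wide uncertainty. In this assay compound 4 is estimated at 8000 nM, with a range from 1000 nM to 60000 nM.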

Compound 4, half-maximal inhibitory concentration: "not active" (no number reported)
Nothing numeric was reported for compound 4, and the estimate cannot be compared.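

In this assay compound 3 and compound 4 both stand without a number, so no step can be read between them. The compounds shown leave open whether 4-methylphenyl and 3-bromo-4-fluorophenyl differ in this read-out, and no supporting data bear on the result.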